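Dropping One Methoxy Group: What to Expect for Compound 4

The source may hold more compounds than are shown below. What is called first, only, known or untested is meant among the compounds shown, and "the series" means these compounds.

Compound 2 `COc1cc(-c2cc(/C=C/C(=O)c3ccc(N)cc3)[nH]n2)cc(OC)c1OC` is one of three compounds tested in a functional assay on SNB-19 cells (Homo sapiens) for cytotoxicity, read by sulforhodamine B assay, with a stated time of 48 h, tested at 0.1 uM; a higher number here means a weaker effect of the compound at the concentration tested, a lower number a stronger effect. In this assay compound 2 gives 94%. Compound 1 `COc1ccc(-c2cc(/C=C/C(=O)c3ccc(N)cc3)[nH]n2)cc1` gives 89%, and compound 3 `COc1ccc(C(=O)/C=C/c2cc(-c3cc(OC)c(OC)c(OC)c3)n[nH]2)cc1` gives 88%; all three numbers lie within the usual scatter of one another, so none of them stands apart. Compound 4 `COc1ccc(-c2cc(/C=C/C(=O)c3ccc(N)cc3)[nH]n2)cc1OC` differs from compound 2 in one place: hydrogen in place of methoxy on an aromatic carbon. Among the measured compounds shown here, the only measured step, a number 6 percentage points lower from compound 2 to compound 3 (within the scatter), concerns a different exchange and stayed within the scatter. For the measured compounds named here, no measured step removes a methoxy group, so the expectation rests on the narrow spread of the three numbers. Compound 4 is therefore estimated to give 92%, between 82% and 100%. The expected step is a number 2 percentage points lower from compound 2 to compound 4 (within the scatter), within the scatter.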

Compound 4, a percentage reported as activity, at one concentration (the size of the read-out at that concentration, not a potency): 90%
Estimate against measurement, compound 4: 2 percentage points above, within the range that was stated.
By their numbers in this assay, from the lowest: compounds 3, 1, 4 and 2 (each within the scatter of the next).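

In this assay, hydrogen in place of methoxy gives a number 4 percentage points lower from compound 2 to compound 4 (within the scatter), and methoxy in place of hydrogen gives a number 1 percentage points higher from compound 1 to compound 4 (within the scatter). Both exchanges on this ring stay within the scatter, so at this single concentration, adding or removing a methoxy group here has no readable effect in either direction. Nothing available explains this result. Still open, going by these compounds, is whether a different group on this aromatic carbon, such as a hydroxyl or a chlorine atom, would move the number, and whether these compounds would separate at higher concentrations.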